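A few compounds are considered here, and "the series" means these few. Any claim that something is new, unique, unknown or untested is made for them only; others in the source may bear on it.

Three compounds share one core and differ only in a single aromatic group. Compound 1 `Cc1cccc(-c2cc(-c3ccc(Cl)o3)cc(-c3ccsc3)n2)c1` gives 20200 nM in a functional assay on K562 cells (Homo sapiens) for cytotoxicity, in the presence of a further agent that is not named here; on this read-out higher numbers stand for weaker inhibition and lower numbers for stronger inhibition. Compound 2 `Cc1ccc(-c2cc(-c3ccc(Cl)o3)cc(-c3ccsc3)n2)o1` gives 23300 nM in this assay, and compound 3 `Cc1ccc(-c2cc(-c3ccc(Cl)o3)cc(-c3ccsc3)n2)cc1` gives 19900 nM in this assay. Compound 3 holds the lowest of the three numbers, yet the step of a 1.0-fold lower number from compound 1 to compound 3 (0.01 log units; within the scatter) and the step of a 1.2-fold lower number from compound 2 to compound 3 (0.07 log units; within the scatter) both lie within the scatter, so the three compounds cannot be told apart on these numbers.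

Compound 4 `Clc1ccc(-c2cc(-c3ccsc3)nc(-c3ccccn3)c2)o1` has not yet been measured. It differs from compound 3 in one place: pyridin-2-yl in place of 4-methylphenyl on an aromatic carbon. Going by the values given here, two measured steps bear on this change. The step of a 1.2-fold lower number from compound 2 to compound 3 (0.07 log units; within the scatter) swapped one aromatic ring for another kind of aromatic ring, and the step of a 1.2-fold higher number from compound 1 to compound 2 (0.06 log units; within the scatter) did the same in the other direction; neither moved the number beyond the scatter. The change to compound 4 is again an exchange of one aromatic ring for another, so no step beyond the scatter is expected in this assay. For compound 4 the expected step is a 1.0-fold higher number from compound 3 to compound 4 (0.00 log units; within the scatter). Compound 4 is therefore estimated at 20000 nM in this assay, with a range from 8000 nM to 50000 nM.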

Compound 4, half-maximal inhibitory concentration: 21900 nM
Estimate against measurement, compound 4: 1.1-fold (0.04 log units) below, within the range that was stated.
By their numbers in this assay, from the lowest: compounds 3, 1, 4 and 2 (each within the scatter of the next).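

Going by these compounds alone, compound 4 places a ring nitrogen at this position for the first time: pyridin-2-yl, next to the ring nitrogen of the shared core, has one hydrogen-bond acceptor where 4-methylphenyl has none, and unlike the three earlier groups, it carries no methyl group. In this assay, the change from 4-methylphenyl gives a small step (a 1.1-fold higher number from compound 3 to compound 4 (0.04 log units; within the scatter)), and the comparisons with the other two compounds are just as small (a 1.1-fold lower number from compound 2 to compound 4 (0.03 log units; within the scatter); a 1.1-fold higher number from compound 1 to compound 4 (0.04 log units; within the scatter)). The series therefore now includes a six-membered ring with a nitrogen as well as a carbon-only ring and a methylfuran, and none of these exchanges moves the number beyond the scatter.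

No measurement shown here gives a reason for this flat result. From the compounds shown here alone, all four groups at this position are aromatic rings, so it remains open whether an amine, a carboxylic acid or a longer carbon chain there would shift the number, and what changing the 5-chlorofuran-2-yl or thiophen-3-yl group would do.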